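The source may report more compounds than this note shows. Statements on the series, on what has been measured and on what is new or still open speak of the compounds shown alone.

Compound 1 `CC(CCCCOc1ccccc1CN(C)C(=O)c1ccc(-c2ccco2)cc1)C(=O)O` is one of two compounds with a number in an ADME assay on the whole organism (strain CD-1) for pharmacokinetics, with Mus musculus as the target, at a dose of 3 mg/kg by the intravenous route (a higher number here means more compound in the circulation at the dose given, a lower number less compound in the circulation), and in that assay compound 1 gives 11400 ng.h/mL; this is the lowest of the two numbers shown. Going by the values given here, its one neighbour, compound 2 `CN(Cc1ccccc1OCCC[C@@H]1C[C@H]1C(=O)O)C(=O)c1ccc(-c2ccco2)cc1`, gives 40500 ng.h/mL in this assay, and the step of a 3.6-fold higher number from compound 1 to compound 2 (0.55 log units; beyond the scatter) is the only measured step in the set.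

Compound 3 `CN(Cc1ccccc1OCCC/C=C/C(=O)O)C(=O)c1ccc(-c2ccco2)cc1` has not yet been measured in this assay. It differs from compound 1 at the same position that the measured step altered: 2-carboxyethenyl in place of 2-carboxypropyl on a saturated chain carbon, three bonds along the chain from an oxygen on an aromatic ring

Among the compounds with values here, the only step that bears on the change is that from compound 1 to compound 2, since it too replaces the 2-carboxypropyl group on the saturated chain carbon three bonds along the chain from the oxygen on the aromatic ring; what enters there differs, however, so its size is only a loose guide. A step upward of modest size or none beyond the scatter is expected, giving a 1.6-fold higher number from compound 1 to compound 3 (0.20 log units; within the scatter) as the estimated step. For compound 3 the expected number in this assay is 18000 ng.h/mL, with a range from 7000 ng.h/mL to 45000 ng.h/mL.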

Compound 3, area under the concentration-time curve: 750 ng.h/mL
Beside the measured number, compound 3's estimate is 24-fold (1.38 log units) above it; the measured number lies below the stated range.
By their numbers in this assay, from the lowest: compound 3; then compound 1; then compound 2.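

The result shows that this position, on a saturated chain carbon three bonds along the chain from an oxygen on an aromatic ring, can move the number in this assay strongly downward as well as upward: with 2-carboxyethenyl entering, the result is a 15-fold lower number from compound 1 to compound 3 (1.18 log units; beyond the scatter). Set against the cyclopropane-bearing acid, the gap is wider still, at a 54-fold lower number from compound 2 to compound 3 (1.73 log units; beyond the scatter), so the two replacements for 2-carboxypropyl fall on opposite sides of compound 1. The large drop also comes with a small counted change, one heavy atom fewer and one more double bond outside aromatic rings, while the hydrogen-bond donor and acceptor counts and the net charge stay the same; no measurement offered here accounts for the drop.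

These three compounds leave open whether the low number in this assay follows the double bond itself or the loss of the branch carried by 2-carboxypropyl, a question that a saturated, unbranched 2-carboxyethyl group would help to separate. They also leave open how a longer chain or a cis double bond would behave at this position.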